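Swapping the aryl group at the ring carbon: compound 4

This account rests on a few compounds, and the source may have more. Where it says the series, first, only, none or still open, it means among the compounds named here.

Three compounds share a core carrying a 4-sulfamoylphenyl group and a 5-chloro-2-hydroxy-4-methylphenyl group, and differ only at one saturated ring carbon. Compound 1 `Cc1cc(O)c(C2=NN(c3ccc(S(N)(=O)=O)cc3)C(c3ccccc3O)C2)cc1Cl` bears a 2-hydroxyphenyl group there, and in a functional assay on HCT-15 cells (Homo sapiens) for antiproliferative activity, with a stated time of 48 h (a higher number here means a weaker inhibitor of growth, a lower number a stronger inhibitor of growth), compound 1 gives 13400 nM. Compound 2 `Cc1cc(O)c(C2=NN(c3ccc(S(N)(=O)=O)cc3)C(c3ccccc3Cl)C2)cc1Cl` carries a 2-chlorophenyl group instead, and compound 2 gives 16600 nM; the change is a 1.2-fold higher number from compound 1 to compound 2 (0.09 log units; within the scatter). Compound 3 `Cc1cc(O)c(C2=NN(c3ccc(S(N)(=O)=O)cc3)C(/C=C/c3ccccc3)C2)cc1Cl` carries a 2-phenylethenyl group at that carbon, and compound 3 gives 100000 nM, the highest of the three numbers, so its growth inhibition is the weakest seen here. The two steps that lead to it are a 7.5-fold higher number from compound 1 to compound 3 (0.87 log units; beyond the scatter) and a 6.0-fold higher number from compound 2 to compound 3 (0.78 log units; beyond the scatter).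

Compound 4 `COc1ccc(C2CC(c3cc(Cl)c(C)cc3O)=NN2c2ccc(S(N)(=O)=O)cc2)cc1OC` is not yet measured. Its change from compound 3 is 3,4-dimethoxyphenyl in place of 2-phenylethenyl on a saturated ring carbon. This reverses the kind of move that produced compound 3: an aromatic ring is put back on the saturated ring carbon in place of the 2-phenylethenyl group. Both earlier steps, moving the other way, raised the number by a modest amount beyond the scatter, so a drop of similar size is expected for compound 4, meaning a 6.3-fold lower number from compound 3 to compound 4 (0.80 log units; beyond the scatter). The estimate for compound 4 in this assay is 16000 nM, with a range from 5000 nM to 60000 nM.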

Compound 4, concentration for total growth inhibition: 20200 nM
For compound 4 the middle estimate is 1.3-fold (0.10 log units) below the measured one; low and high end bracket the measured number.
By their numbers in this assay, from the lowest: compounds 1, 2 and 4 (each within the scatter of the next); then compound 3.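

In this assay, among these compounds, a third aryl group on the saturated ring carbon also gives a lower number than 2-phenylethenyl (a 5.0-fold lower number from compound 3 to compound 4 (0.69 log units; beyond the scatter)), so this drop is not limited to the 2-hydroxyphenyl and 2-chlorophenyl groups of the earlier compounds. The 3,4-dimethoxyphenyl group differs clearly from those two in what it carries, since it brings two methoxy groups instead of one hydroxy or chloro group, yet it cannot be separated from either of them (a 1.2-fold higher number from compound 2 to compound 4 (0.09 log units; within the scatter); a 1.5-fold higher number from compound 1 to compound 4 (0.18 log units; within the scatter)). Among these four compounds, the three with an aromatic ring attached directly to that carbon therefore form one group, with compound 3 alone standing apart, and nothing measured here accounts for this split.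

The compounds shown leave open whether the double bond of 2-phenylethenyl matters or only the two-carbon link, a question that the saturated 2-phenylethyl group would address. They also leave open whether a plain phenyl ring, or a phenyl ring carrying an amine or a carboxylic acid, would stay with compounds 1, 2 and 4 or fall nearer to compound 3.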